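The source may hold more compounds than are shown below. What is called first, only, known or untested is meant among the compounds shown, and "the series" means these compounds.

Three compounds share one core, and compound 1 `COc1ccc(Cl)cc1S(=O)(=O)Nc1cncc(-c2cccnc2)c1` and compound 2 `COc1ccc(Cl)cc1S(=O)(=O)Nc1cncc(-c2ccccc2C)c1` are the two for which no result exists: in an assay on isolated protein for inhibition of alkaline phosphatase, tissue-nonspecific isozyme (Homo sapiens) (a higher number here means a weaker inhibitor, a lower number a stronger inhibitor), compound 1 is recorded as "not determined" (no result reported), and compound 2 is recorded as "not determined" (no result reported). Compound 3 `COc1ccc(Cl)cc1S(=O)(=O)Nc1cncc(C(=O)O)c1` carries a carboxy group on that shared core. In this assay compound 3 reaches only a limit, > 20000 nM, and no number within the working range is reported for it. That limit is the single numerical entry among the three, as the summary puts it: the limit of > 20000 nM in this assay, at which 1 of the 3 values shown sits. Among the measured compounds shown here, no step between two measured compounds exists, so there is no measured gradient on which a change could be placed. Compound 4 `COC(=O)c1cncc(NS(=O)(=O)c2cc(Cl)ccc2OC)c1` is the next point; it differs from compound 3 by methyl in place of hydrogen on an oxygen next to a carbonyl group. Since compound 3 sits at a limit, no direction is established, and for compound 4 in this assay the expectation is no step beyond the scatter, a number no higher from compound 3 to compound 4 (the limit leaves the size open). Compound 4 is estimated at 20000 nM, with a range from 5000 nM to 60000 nM, a limit again being the likelier report.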

Compound 4, half-maximal inhibitory concentration: > 20000 nM
Compound 4 ended at the assay's limit (the forecaster's own chance of this, stated with the estimate: 60%); the middle value sits exactly at the limit.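

In this assay compound 3 and compound 4 both end at a limit, so no step can be read between them: the limit of > 20000 nM in this assay, at which 2 of the 4 values shown sit. The compounds shown leave open whether any group on the shared core brings a value inside the working range.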